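Swapping phenyl for furan in a weakly active pair

The source may report more compounds than this note shows. Statements on the series, on what has been measured and on what is new or still open speak of the compounds shown alone.

Compound 1 `Nc1ncc(-c2ccncc2Br)c(C2CC2)n1`: 99000 nM
Compound 2 `Nc1ncc(-c2ccncc2-c2ccccc2)c(C2CC2)n1`: > 100000 nM (a limit)
Compound 3 `Nc1ncc(-c2ccncc2-c2ccoc2)c(C2CC2)n1`: not yet measured

Both measured compounds were tested in a functional assay on CUTLL1 cells (Homo sapiens) for inhibition, read by resazurin assay, with a stated time of 48 h, in the absence of a further agent; on this read-out lower numbers stand for an effect already at smaller amounts and higher numbers for an effect only at larger amounts of compound. Compound 2 stands at the limit of > 100000 nM in this assay, at which 1 of the 2 values shown sits. This is a limit and not a number. Compound 3 carries furan-3-yl in place of phenyl on an aromatic carbon. Going by the values given here, only one measured step bears on this change, a number no lower from compound 1 to compound 2 (the limit leaves the size open), where phenyl took the place of bromo. From the compounds shown here alone, the size of that step stays open. Compound 1 gives 99000 nM, so neither measured compound shows an effect at small amounts. No step beyond the usual scatter is therefore expected in this assay, and no direction can be read from the data. The expected step is an at least 1.2-fold lower number from compound 2 to compound 3 (0.09 log units; that floor lies within the scatter). Compound 3 is expected at 80000 nM, with an estimated range of 25000 nM to 150000 nM.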

Compound 3, half-maximal effective concentration: 28000 nM
Beside the measured number, compound 3's estimate is 2.9-fold (0.46 log units) above it; low and high end bracket the measured number.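

In this assay, going by these compounds alone, the group on this aromatic carbon, two atoms from the ring nitrogen, can move the number beyond the scatter: the change from bromo to furan-3-yl gives a 3.5-fold lower number from compound 1 to compound 3 (0.55 log units; beyond the scatter), whereas the only earlier step had no readable size. Replacing the six-membered carbon ring of phenyl with the five-membered oxygen-containing ring of furan-3-yl gives an at least 3.5-fold lower number from compound 2 to compound 3 (0.55 log units; beyond the scatter), so the choice of aromatic ring at this position matters in this assay. The size of that step is only a floor, as compound 2 stands at a limit and not a number: the limit of > 100000 nM in this assay, at which 1 of the 3 values shown sits.

From the compounds shown here alone, it remains open whether the ring oxygen or the smaller ring size accounts for the gain. Thiophene-3-yl, with sulfur in place of that oxygen, would help to separate the two, and furan-2-yl would test where the oxygen sits.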